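A few compounds are considered here, and "the series" means these few. Any claim that something is new, unique, unknown or untested is made for them only; others in the source may bear on it.

Compound 1, `COCCOc1nc(Nc2ccc(C#N)c(OCC=C(C)C)c2)nc(OC)n1`, in an ADME assay on MT2 cells (Homo sapiens) for cytotoxicity, read by MTT assay (a higher number here means that more compound is tolerated, a lower number that less compound is tolerated), gives 8600 nM.
Compound 2, `COCCOCCOCCOc1nc(Nc2ccc(C#N)c(OCC=C(C)C)c2)nc(OC)n1`, in this assay gives 4200 nM.

Compound 2 stands lowest of the two numbers in this assay, with compound 1 nearest to it. Compound 3, `COc1nc(Nc2ccc(C#N)c(OCC=C(C)C)c2)nc(OCCC2CCCCO2)n1`, differs from compound 2 thus: oxan-2-yl in place of 2-(2-methoxyethoxy)ethoxy on a saturated chain carbon, two bonds along the chain from an oxygen on an aromatic ring. Going by the values given here, the only measured step, a 2.0-fold lower number from compound 1 to compound 2 (0.31 log units; beyond the scatter), had (2-methoxyethoxy)methyl in place of hydrogen and was modest. Here 2-(2-methoxyethoxy)ethoxy leaves and oxan-2-yl enters, so that step bears only loosely, and no step beyond the scatter is expected. Compound 3 is therefore estimated at 6000 nM, within 3000 nM to 12000 nM, a step of a 1.4-fold higher number from compound 2 to compound 3 (0.15 log units; within the scatter).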

Compound 3, half-maximal cytotoxic concentration: 4200 nM
Estimate against measurement, compound 3: 1.4-fold (0.15 log units) above, within the range that was stated.
By their numbers in this assay, from the lowest: compounds 2 and 3 (each within the scatter of the next); then compound 1.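

In this assay, replacing the open 2-(2-methoxyethoxy)ethoxy chain with the ring of oxan-2-yl, on a saturated chain carbon two bonds along the chain from an oxygen on an aromatic ring, gives no change at the digits printed from compound 2 to compound 3 (within the scatter), so a ring here reads the same as the chain. Oxan-2-yl in place of methoxy gives a 2.0-fold lower number from compound 1 to compound 3 (0.31 log units; beyond the scatter), a modest step like the one the chain produced. Nothing available explains why these two different groups read alike.

As far as these compounds go, whether an amine or a carboxylic acid at this place would move the number remains open.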